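A few compounds are considered here, and "the series" means these few. Any claim that something is new, unique, unknown or untested is made for them only; others in the source may bear on it.

Measured compounds:
Compound 1, `CCCCCCCC/C=C\CCCCCCCC(OC)OC` — in an assay on isolated protein for inhibition of Fatty-acid amide hydrolase 1 (Homo sapiens) (a higher number here means a weaker inhibitor, a lower number a stronger inhibitor), compound 1 gives > 300000 nM
Compound 2, `CCCCCCCC/C=C\CCCCCCC(=O)c1nc2cc(C)ccc2o1` — in this assay compound 2 gives > 100000 nM

Both numbers are limits of this assay and not measured values. Compound 1 gives only a limit in this assay. Compound 2 likewise gives only a limit in this assay. Where compound 2 stands can therefore be said only in terms of the limit at which it sits, (the limit of > 100000 nM in this assay, at which 1 of the 2 values shown sits); the one other value shown is also a limit, the one at the limit of > 300000 nM in this assay, at which 1 of the 2 values shown sits. Among the compounds with values here, no step between measured compounds that differ in one place is available, so no measured change in this assay can be described.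

Compound 3, `CCCCCCCC/C=C\CCCCCCC(=O)c1nc2ccccc2o1`, has not yet been measured in this assay. It differs from compound 2 in one place: hydrogen in place of methyl on an aromatic carbon.

With nothing but two limits in hand, the step from compound 2 to compound 3 is expected to be no larger than the scatter of this assay, in no preferred direction, a step that the limit leaves unreadable from compound 2 to compound 3. For compound 3 the expected value in this assay is 150000 nM, with a range from 40000 nM to 600000 nM, and the most likely outcome is that the assay again reports only a limit.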

Compound 3, inhibition constant: 370 nM
Compound 3: the middle estimate sits 410-fold (2.61 log units) above what was measured; measured number outside the range, below it.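

In this assay, within the data shown here, hydrogen in place of methyl on an aromatic carbon gives an at least 270-fold lower number from compound 2 to compound 3 (2.43 log units; beyond the scatter), and this is the first change that can be read at all. It shows that this one carbon of the six-membered aromatic ring is highly sensitive: a single methyl, one heavy atom, separates compound 2 from compound 3. Compound 3 has a measured value of 370 nM. Compound 2 reaches only a limit. The full size of the step cannot be stated because compound 2 gives only a limit and not a number: the limit of > 100000 nM in this assay, at which 1 of the 3 values shown sits.

On these data alone, only hydrogen and methyl are compared at this carbon, so it remains open whether a fluorine, a chlorine or a methoxy group there would behave like the hydrogen of compound 3 or like the methyl of compound 2, and whether methyl on another carbon of the same ring would have the same outcome. As far as these compounds go, it also remains open how the core of compound 3 would respond to changes elsewhere, such as a shorter chain or an amide in place of the carbonyl.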